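The source may hold more compounds than are shown below. What is called first, only, known or untested is meant among the compounds shown, and "the series" means these compounds.

In a functional assay on WM 266-4 cells (Homo sapiens) for antiproliferative activity, read by MTT assay, with a stated time of 48 h (a higher number here means a weaker inhibitor, a lower number a stronger inhibitor), compound 1 `O=C(Nc1cc(-c2ccccc2)[nH]n1)c1ccc(Br)nc1` gives 6730 nM and compound 2 `O=C(Nc1cc(-c2ccc(Br)cc2)[nH]n1)c1cccnc1Cl` gives 6990 nM. These two numbers lie within the usual scatter of repeated measurements, so compound 2 stands level with compound 1 and neither can be ranked above the other. The two structures differ in more than one place, so this pair does not isolate any single change.

The next molecule, compound 3 `O=C(Nc1cc(-c2ccc(Br)cc2)[nH]n1)c1ccc(Br)nc1`, differs from compound 2 in one place: 6-bromopyridin-3-yl in place of 2-chloropyridin-3-yl on a carbonyl carbon. In words, 6-bromopyridin-3-yl stands in place of 2-chloropyridin-3-yl on a carbonyl carbon. Within the data shown here, no measured pair shows this swap alone, so any forecast rests on thin evidence. Compound 1 also carries 6-bromopyridin-3-yl and gives 6730 nM, which offers no sign of a large shift. No step beyond the scatter is therefore expected in this assay. The expected change is small, a 1.3-fold lower number from compound 2 to compound 3 (0.10 log units; within the scatter), and its direction is uncertain. The estimate for compound 3 is 5500 nM, with an expected range from 2000 nM to 15000 nM.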

Compound 3, half-maximal inhibitory concentration: 8560 nM
The estimate for compound 3 lay 1.6-fold (0.19 log units) below the measured number; low and high end bracket the measured number.
By their numbers in this assay, from the lowest: compounds 1, 2 and 3 (each within the scatter of the next).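

Among these compounds, these two steps are the first single changes that can be read. In this assay the exchange of 2-chloropyridin-3-yl for 6-bromopyridin-3-yl on the carbonyl carbon gives a 1.2-fold higher number from compound 2 to compound 3 (0.09 log units; within the scatter) and so leaves the number without a real shift, even though the halogen and its place on the pyridine ring both differ. Bromo in place of hydrogen on an aromatic carbon, with the 6-bromopyridin-3-yl group held the same, gives a 1.3-fold higher number from compound 1 to compound 3 (0.10 log units; within the scatter) and likewise shows no real shift, so neither change separates these compounds in this assay. No supporting measurement bears on why these numbers stay so close, and the result alone cannot say.

As far as these compounds go, only hydrogen, bromo and a halogen-bearing pyridine ring appear at these two places, so it remains open whether an amine, a methoxy group or a carboxylic acid in place of the bromo on the aromatic carbon would move the number beyond the scatter. Equally open, from the compounds shown here alone, is what a group without a pyridine ring, such as a cyclohexyl ring or a longer alkyl chain, would do on the carbonyl carbon.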